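A few compounds are considered here, and "the series" means these few. Any claim that something is new, unique, unknown or untested is made for them only; others in the source may bear on it.

Compound 1 `Cc1cc(-c2c(C)nn(C)c2C)ccc1-c1nnc(N(C)Cc2ccc3nccn3c2)o1`: 398 nM
Compound 2 `Cc1cc(-c2c(C)nn(C)c2C)cnc1-c1nnc(N(C)Cc2ccc3nccn3c2)o1`: 6310 nM
Compound 3 `Cc1cc(-c2c(C)nn(C)c2C)ccc1-c1nnc(N(C)Cc2ccc3ncc(-c4cnn(CCN(C)C)c4)n3c2)o1`: 126 nM

These three compounds were tested in an assay on COS-7 cells for inhibition of tyrosine-protein kinase receptor UFO (Homo sapiens), read by ELISA, with a stated time of 1 h; on this read-out higher numbers stand for weaker inhibition and lower numbers for stronger inhibition. Compound 4 `Cc1cc(-c2c(C)nn(C)c2C)cnc1-c1nnc(N(C)Cc2ccc3ncc(-c4cnn(CCN(C)C)c4)n3c2)o1` is not yet measured there. Compound 3 differs from compound 1 by 1-(2-(dimethylamino)ethyl)-1H-pyrazol-4-yl in place of hydrogen on an aromatic carbon; in this assay that change gave a 3.2-fold lower number from compound 1 to compound 3 (0.50 log units; beyond the scatter). Compound 4 differs from compound 2 by 1-(2-(dimethylamino)ethyl)-1H-pyrazol-4-yl in place of hydrogen on an aromatic carbon, the same change at the same place. How the core of compound 2 differs from the core of compound 1 is not broken down here; in this assay compound 2 gives the highest number of the three measured compounds. The step from compound 2 to compound 4 is expected to be a 3.2-fold lower number from compound 2 to compound 4 (0.50 log units; beyond the scatter), because the same change gave a 3.2-fold lower number from compound 1 to compound 3 (0.50 log units; beyond the scatter). Compound 4 is therefore expected to give about 2000 nM, estimated to lie between 800 nM and 5000 nM.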

Compound 4, half-maximal inhibitory concentration in the tyrosine-protein kinase receptor UFO assay: 1000 nM
Estimate against measurement, compound 4: 2.0-fold (0.30 log units) above; the range from low to high includes it.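

In the tyrosine-protein kinase receptor UFO assay compound 4 gives 1000 nM. In the tyrosine-protein kinase receptor UFO assay, putting 1-(2-(dimethylamino)ethyl)-1H-pyrazol-4-yl in place of hydrogen on an aromatic carbon gave a 6.3-fold lower number from compound 2 to compound 4 (0.80 log units; beyond the scatter). Set beside the earlier step, the change carried over from one core to the other in the same direction and to a size that cannot be told apart: the same change on two cores in the tyrosine-protein kinase receptor UFO assay, a 3.2-fold lower number (0.50 log units; beyond the scatter) from compound 1 to compound 3 and a 6.3-fold lower number (0.80 log units; beyond the scatter) from compound 2 to compound 4, 2.0-fold (0.30 log units) apart, within the scatter of two such steps. Within the data shown here, this rests on only two cores, so it does not show that the change would transfer to other cores, and it does not show why the number falls. In a physicochemical assay for lipophilicity, at pH 7.4 (a higher number here means a more lipophilic compound, a lower number a more polar compound), compound 2 gives 2.8 and compound 4 gives 2.7, two values within the scatter of each other.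

The compounds shown leave open which part of the added group matters. A plain methyl on the pyrazole nitrogen, or a morpholine at the end of the chain, could help to separate the pyrazole ring from the dimethylamino group.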